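Adding 2-methoxyethyl to a sulfonamide nitrogen

The compounds below may be only part of what the source reports. "The series", "measured", "known", "first", "only" and "open" are said of these compounds alone.

In a physicochemical assay for solubility, with a stated time of 24 h, tested at 30 mg/mL (a lower number here means a less soluble compound, a higher number a more soluble compound), compound 3 (`Cc1cc(COc2ccc(S(=O)(=O)NC3(C(=O)NO)CN(C(=O)C(C)C)C3)cc2)c2ccccc2n1`) gives 17000000 nM as its reading. Among the measured compounds shown here, compound 1 (`CC(=O)N1CC2(C1)CC(NS(=O)(=O)c1ccc(OCc3cc(C)nc4ccccc34)cc1)(C(=O)NO)C2`) stands level with it at 17000000 nM as its own reading, and together they hold the top of the three numbers known so far. Compound 2 (`CC(=O)N1CC2(C1)CC(CC(=O)NO)(NS(=O)(=O)c1ccc(OCc3cc(C)nc4ccccc34)cc1)C2`) sits lowest at 3000000 nM on the same scale.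

Compound 4 (`COCCN(C1(C(=O)NO)CN(C(=O)C(C)C)C1)S(=O)(=O)c1ccc(OCc2cc(C)nc3ccccc23)cc1`) is compound 3 with 2-methoxyethyl in place of hydrogen on a sulfonamide nitrogen. For the measured compounds named here, no measured compound carries anything but hydrogen on that nitrogen, so no measured step speaks directly to this change. Going by the values given here, the only guide to size is a 5.7-fold lower number from compound 1 to compound 2 (0.75 log units; beyond the scatter) when (hydroxycarbamoyl)methyl takes the place of hydroxycarbamoyl on a saturated ring carbon, which is a different kind of change. Taking that as a rough scale, a modest fall is expected in this assay for the new compound, starting as it does from the top of the known numbers. No change beyond the scatter remains quite possible. The expected change is a 1.9-fold lower number from compound 3 to compound 4 (0.28 log units; within the scatter) by this estimate. For compound 4 the estimated value is 9000000 nM within a range running from 2500000 nM at the low end to 28000000 nM at the high end.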

Compound 4, solubility: 8900000 nM
For compound 4 the middle estimate is 1.0-fold (0.00 log units) above the measured one, and the stated range covers the measured number.
By their numbers in this assay, from the lowest: compound 2; then compounds 4, 1 and 3 (each within the scatter of the next).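

Among the compounds shown here, compound 4 is the first compound here with anything other than hydrogen on the sulfonamide nitrogen, so this position, whose other neighbours are a saturated ring carbon and the sulfonyl sulfur, now has a direct reading of its own. In this assay the swap of that hydrogen for 2-methoxyethyl, a chain of 4 heavy atoms with no ring and no net charge, gives a 1.9-fold lower number from compound 3 to compound 4 (0.28 log units; within the scatter) and so does not separate the two compounds, which means this nitrogen can carry such a chain with no change beyond the scatter in this one assay. No accompanying measurement offers an explanation for this outcome.

On these data alone, a single chain on a single core is a narrow basis, so it remains open whether a small methyl, a longer chain, a chain ending in an amine or one ending in a carboxylic acid would also stay within the scatter. As far as these compounds go, it is equally open whether 2-methoxyethyl on this nitrogen would give a similar result on the core of compound 1, or with an acetyl group in place of the 2-methylpropanoyl group of compound 3.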